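The source may hold more compounds than are shown below. What is called first, only, known or untested is meant among the compounds shown, and "the series" means these compounds.

Compound 3 `N#CC1=C(N)Oc2c(c3nc4ccccc4nc3c3ccccc23)C12C(=O)N(Cc1cnnn1-c1ccc(Br)cc1)c1ccccc12` is measured in a functional assay on A549 cells (Homo sapiens) for antiproliferative activity, read by MTT assay, with a stated time of 48 h (on this read-out higher numbers stand for weaker inhibition and lower numbers for stronger inhibition), at 44300 nM. That is the highest of the three numbers in hand, though it stands apart from neither companion: compound 1 `Cc1cccc(-n2nncc2CN2C(=O)C3(C(C#N)=C(N)Oc4c3c3nc5ccccc5nc3c3ccccc43)c3ccccc32)c1` gives 39600 nM in this assay, and compound 2 `N#CC1=C(N)Oc2c(c3nc4ccccc4nc3c3ccccc23)C12C(=O)N(Cc1cnnn1-c1cccc(Cl)c1)c1ccccc12` gives 32600 nM. The step of a 1.1-fold higher number from compound 1 to compound 3 (0.05 log units; within the scatter) and the step of a 1.4-fold higher number from compound 2 to compound 3 (0.13 log units; within the scatter) are both within the scatter, as is a 1.2-fold lower number from compound 1 to compound 2 (0.08 log units; within the scatter).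

Compound 4 `N#CC1=C(N)Oc2c(c3nc4ccccc4nc3c3ccccc23)C12C(=O)N(Cc1cnnn1-c1cccc(Br)c1)c1ccccc12` differs from compound 3 in one place: 3-bromophenyl in place of 4-bromophenyl on an aromatic nitrogen. For the measured compounds named here, the steps that bear on it are those that already exchange the group on the aromatic nitrogen, a 1.1-fold higher number from compound 1 to compound 3 (0.05 log units; within the scatter) and a 1.4-fold higher number from compound 2 to compound 3 (0.13 log units; within the scatter), where 3-methylphenyl and 3-chlorophenyl were replaced by 4-bromophenyl without a shift beyond the scatter. Moving the bromine within the same ring is therefore expected to leave the number essentially unchanged, with a 1.2-fold lower number from compound 3 to compound 4 (0.07 log units; within the scatter) expected to fall within the scatter. Compound 4 is accordingly estimated at 38000 nM in this assay, with a range from 19000 nM to 76000 nM.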

Compound 4, half-maximal inhibitory concentration: > 50000 nM
Compound 4: a limit, no number; the forecaster's own chance of this, stated with the estimate: 10%; middle value at least 1.3-fold (0.11 log units) from the limit.
By their numbers in this assay, from the lowest: compounds 2, 1 and 3 (each within the scatter of the next). At a limit, above all of these: compound 4.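

Compound 4 in this assay returns a limit and not a number: the limit of > 50000 nM in this assay, at which 1 of the 4 values shown sits. Moving the bromine, which turns 4-bromophenyl into 3-bromophenyl on the aromatic nitrogen, gives an at least 1.1-fold higher number from compound 3 to compound 4 (0.05 log units; that floor lies within the scatter), while the two comparisons on an aromatic carbon give an at least 1.5-fold higher number from compound 2 to compound 4 (0.18 log units; that floor lies within the scatter) and an at least 1.2-fold higher number from compound 1 to compound 4 (0.10 log units; that floor lies within the scatter). Each of these is only a floor lying within the scatter, so the series shows no real change from these exchanges, yet it no longer rules one out, as the steps among compounds 1, 2 and 3 did within their scatter.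

Going by these compounds, how far compound 4 lies beyond its limit remains open. So does whether an amine, a carboxylic acid or a methoxy group on this phenyl ring would shift the number beyond the scatter.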